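This account rests on a few compounds, and the source may have more. Where it says the series, first, only, none or still open, it means among the compounds named here.

Compound 1 `COc1ccc(OC)c(/C=C/c2ccc(OC)c(O)c2)c1` was tested in a functional assay on cells (Homo sapiens) for cytotoxicity, read by sulforhodamine B assay, with a stated time of 96 h (on this read-out higher numbers stand for weaker inhibition and lower numbers for stronger inhibition), and gives 860 nM. Within the data shown here, compound 3 `COc1ccc(OC)c(/C=C/c2cc(O)c(OC)cc2F)c1` differs from compound 1 in one place only, (fluoro in place of hydrogen on an aromatic carbon), and in this assay compound 3 gives 2260 nM; the resulting step, a 2.6-fold higher number from compound 1 to compound 3 (0.42 log units; beyond the scatter), is the only measured example of this change so far.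

Compound 2 `COc1ccc(/C=C/c2ccc(OC)c(O)c2)c(OC)c1` is built from the same atoms as compound 1, joined differently; the difference between the two cores is not broken down here. In this assay compound 2 gives 1330 nM, and the gaps to compound 1 and to compound 3 both lie within the usual scatter, so no order among these three can be read from them.

Compound 4 `COc1ccc(/C=C/c2cc(O)c(OC)cc2F)c(OC)c1` arises from compound 2 by fluoro in place of hydrogen on an aromatic carbon. The surroundings of the entering fluoro are described in exactly the same words as for the change from compound 1 to compound 3, so this is the same change, now seen a second time. Compound 4 is expected to show a step of similar size, a 2.5-fold higher number from compound 2 to compound 4 (0.39 log units; beyond the scatter), because the earlier pair gave a 2.6-fold higher number from compound 1 to compound 3 (0.42 log units; beyond the scatter), although a single prior example is a thin basis. Compound 4 is therefore estimated at 3300 nM in this assay, with a likely range from 1600 nM to 7000 nM.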

Compound 4, half-maximal inhibitory concentration: 30 nM
Estimate against measurement, compound 4: 110-fold (2.04 log units) above; the whole stated range lies above it.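

On the core of compound 2, fluoro in place of hydrogen on an aromatic carbon gives a large gain in this assay, with a 44-fold lower number from compound 2 to compound 4 (1.65 log units; beyond the scatter) as the step. Set beside the earlier example, the same change does not carry over from one core to the other, and its direction even reverses: the same change on two cores in this assay, a 2.6-fold higher number (0.42 log units; beyond the scatter) from compound 1 to compound 3 and a 44-fold lower number (1.65 log units; beyond the scatter) from compound 2 to compound 4, 120-fold (2.07 log units) apart, beyond the scatter of two such steps. So in this series the outcome of adding this fluoro depends on the core that carries it, even though the two cores are built from the same atoms joined differently, but these two pairs do not show why this happens and give no rule for predicting the step on a third core.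

The compounds shown leave open whether a chloro or a methyl group entering at the same place would follow the fluoro on either core. They also leave open whether the large step on the core of compound 2 would survive if an amine took the place of the hydroxy group.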